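A few compounds are considered here, and "the series" means these few. Any claim that something is new, unique, unknown or untested is made for them only; others in the source may bear on it.

Two compounds of the series have numbers in an assay on CHO cells for binding affinity to D(4) dopamine receptor (Homo sapiens); a higher number here means a weaker inhibitor, a lower number a stronger inhibitor. Compound 1 `O=C1NC(CCN2CCN(c3ccc4ccccc4c3)CC2)c2ccccc21` gives 10 nM. Compound 2 `Cc1ccnc(N2CCN(CCC3NC(=O)c4ccccc43)CC2)c1` gives 22.6 nM, the higher of the two numbers, and its gap to compound 1 lies beyond the scatter. Compound 3 `O=C1NC(CCN2CCN(c3ccc(Cl)cc3)CC2)c2ccccc21` has not yet been measured; it carries 4-chlorophenyl in place of 4-methylpyridin-2-yl on an amine nitrogen in a ring. Among the measured compounds shown here, no measured pair shows this change, so the step can only be guessed from the two numbers at hand. The expected step is a 1.5-fold lower number from compound 2 to compound 3 (0.18 log units; within the scatter), a modest drop in the number. Compound 3 is therefore expected at 15 nM in this assay, with a range from 5 nM to 50 nM.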

Compound 3, inhibition constant: 27.8 nM
Compound 3: the middle estimate sits 1.9-fold (0.27 log units) below what was measured, within the range that was stated.
By their numbers in this assay, from the lowest: compound 1; then compounds 2 and 3 (each within the scatter of the next).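

In this assay, 4-chlorophenyl in place of 4-methylpyridin-2-yl on the amine nitrogen in the ring gives a 1.2-fold higher number from compound 2 to compound 3 (0.09 log units; within the scatter) and so leaves the two compounds indistinguishable. In this pair, the ring nitrogen and its hydrogen-bond acceptor can therefore be exchanged for a carbon-only ring bearing chlorine with no step beyond the scatter. Nothing at hand accounts for this result. Still open, going by these compounds, is whether this tolerance extends beyond these two aromatic rings. A carboxylic acid or a primary amine on the ring at this place would test that.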